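The compounds below may be only part of what the source reports. "The series", "measured", "known", "first", "only" and "open" are said of these compounds alone.

Compound 3 `Fc1ccnc(Nc2cc3[nH]c(-c4ccc(F)c(F)c4)nc3cn2)c1` remains at 18% in an ADME assay on microsomes from liver (Mus musculus) for metabolic stability, read by LC-MS, with a stated time of 30 min, tested at 0.1 uM (on this read-out lower numbers stand for a less stable compound and higher numbers for a more stable compound), whereas compound 1 `Fc1ccc(-c2nc3cnc(Nc4cc(C(F)(F)F)ccn4)cc3[nH]2)cc1F` gives 78% in this assay; the change between them is trifluoromethyl in place of fluoro on an aromatic carbon, and it made the step of a number 60 percentage points higher from compound 3 to compound 1 (beyond the scatter). Compound 2 `Fc1ccc(Nc2cc3[nH]c(-c4ccc(F)c(F)c4)nc3cn2)nc1` gives 72% in this assay. Its core differs from that of compound 3 by 5-fluoropyridin-2-yl in place of 4-fluoropyridin-2-yl on a nitrogen on an aromatic ring, and the step was a number 54 percentage points lower from compound 2 to compound 3 (beyond the scatter). Compound 4 `Fc1ccc(Nc2cc3[nH]c(-c4ccc(F)c(C(F)(F)F)c4)nc3cn2)nc1` is not yet measured; it differs from compound 2 by trifluoromethyl in place of fluoro on an aromatic carbon, the same kind of change as from compound 3 to compound 1, though here the place is on a six-membered aromatic ring of carbon only, ortho to a fluoro group, whereas there it was on a ring with 1 nitrogen, opposite the ring nitrogen. Compound 2 leaves less room upward than compound 3 did. Compound 4 is expected to shift by a number 6 percentage points higher from compound 2 to compound 4 (within the scatter). This rests on compound 2 giving 72% and on the step of a number 60 percentage points higher from compound 3 to compound 1 (beyond the scatter). Compound 4 is estimated at 78%, between 60% and 92%.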

Compound 4, percent of the compound remaining: 88%
Compound 4: the middle estimate sits 10 percentage points below what was measured, within the range that was stated.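

In this assay, trifluoromethyl in place of fluoro on the six-membered aromatic ring of carbon only gave a step of a number 16 percentage points higher from compound 2 to compound 4 (beyond the scatter). Set beside the earlier case, the direction held on both cores but the size did not carry over: the same change on two cores in this assay, a number 60 percentage points higher (beyond the scatter) from compound 3 to compound 1 and a number 16 percentage points higher (beyond the scatter) from compound 2 to compound 4, 44 percentage points apart, beyond the scatter of two such steps With only two such pairs, which also differ in the ring that bears the change and in their starting values, this does not show what sets the size of the step.

The compounds shown leave open whether a nitrile or a methyl group on the same aromatic carbon would behave as trifluoromethyl does in this assay. On these data alone, whether the rise would recur on a third core also stays open.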